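A few compounds are considered here, and "the series" means these few. Any claim that something is new, unique, unknown or untested is made for them only; others in the source may bear on it.

Compound 1 `COc1ccc(-c2nc(-c3c[nH]c4ccccc34)co2)cc1OC`: 278000 nM
Compound 2 `Oc1ccc(-c2nc(-c3c[nH]c4ccccc34)co2)cc1`: 449000 nM

Both were tested in a functional assay on LNCaP cells (Homo sapiens) for cytotoxicity, read by MTT assay, with a stated time of 48 h; a higher number here means a weaker inhibitor, a lower number a stronger inhibitor. Among the measured compounds shown here, compound 2 gives the higher of the two numbers, but its only neighbour, compound 1, sits within the scatter, so no order between them can be read. Compound 3 `COc1cc(-c2nc(-c3c[nH]c4ccccc34)co2)ccc1O` has not been measured; it differs from compound 2 by methoxy in place of hydrogen on an aromatic carbon. For the measured compounds named here, no measured pair shows this change, so the step from compound 2 to compound 3 in this assay is expected to be small, in either direction, or none beyond the scatter. Compound 3 is expected to give about 350000 nM, within a range of 150000 nM to 800000 nM. That expectation corresponds to a step of a 1.3-fold lower number from compound 2 to compound 3 (0.11 log units; within the scatter).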

Compound 3, half-maximal inhibitory concentration: 445000 nM
Estimate against measurement, compound 3: 1.3-fold (0.10 log units) below; the measured number falls inside the stated range.
By their numbers in this assay, from the lowest: compounds 1, 3 and 2 (each within the scatter of the next).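

Methoxy in place of hydrogen on the aromatic carbon ortho to the hydroxy group gives a 1.0-fold lower number from compound 2 to compound 3 (0.00 log units; within the scatter) in this assay, so this position shows no readable change with this group. Hydrogen in place of methyl on an oxygen on the aromatic ring gives a 1.6-fold higher number from compound 1 to compound 3 (0.20 log units; within the scatter) and so also shows no readable change, leaving the hydroxy and methoxy forms of that oxygen indistinguishable here. No supporting measurement is available to explain these results.

From the compounds shown here alone, whether an amine or a carboxylic acid on this aromatic carbon would give a step beyond the scatter remains open.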